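The source may hold more compounds than are shown below. What is called first, only, known or untested is meant among the compounds shown, and "the series" means these compounds.

Compound 3, `C=CCSc1nnc(-c2cc(OC)c(OC)c(OC)c2)n1N1C(=O)c2ccccc2C1=O`, was tested in a functional assay on MKN-45 cells (Homo sapiens) for cytotoxicity, read by MTT assay, with a stated time of 48 h (a higher number here means a weaker inhibitor, a lower number a stronger inhibitor), where a higher number means a weaker inhibitor and a lower number a stronger one. In this assay compound 3 gives only the limit > 200000 nM, not a number. That is where all three measured compounds stand, since the limit of > 200000 nM in this assay, at which 3 of the 3 values shown sit, describes every value shown. Compound 1, `CCCc1nnc(SCC(=O)c2ccc(C)cc2)n1N1C(=O)c2ccccc2C1=O`, gives the limit > 200000 nM in this assay. Compound 2, `CCCc1nnc(SC)n1N1C(=O)c2ccccc2C1=O`, gives the limit > 200000 nM in this assay. Going by the values given here, the single step between two measured compounds that differ in one place, a step that the two limits leave unreadable from compound 1 to compound 2, is therefore unreadable from the two limits, and it says nothing about the direction of change on a saturated chain carbon bound to a sulfur. Compound 4, `COc1cc(-c2nnc(SCC(=O)c3ccccc3)n2N2C(=O)c3ccccc3C2=O)cc(OC)c1OC`, differs from compound 3 by benzoyl in place of vinyl on a saturated chain carbon bound to a sulfur, a benzoyl in place of vinyl on a saturated chain carbon bound to a sulfur. Among the compounds with values here, none of the measured steps bears a readable size on this change, and the limit of compound 1, which already carries an aryl ketone at that place, gives no sign of potency. Compound 4 is therefore expected to behave like compound 3, with a step of a number no higher from compound 3 to compound 4 (the limit leaves the size open) that is not expected to exceed the scatter. In this assay compound 4 is estimated at 200000 nM, within a range from 60000 nM to 400000 nM.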

Compound 4, half-maximal inhibitory concentration: > 200000 nM
Compound 4 ended at the assay's limit; the forecaster's own chance of this, stated with the estimate: 85%; the middle value sits exactly at the limit.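

In this assay compound 4 gives > 200000 nM, which is a limit and not a number. Compound 3 also stands at a limit, so no step can be read between compound 3 and compound 4. The compounds shown leave open whether any change on the shared core would give a readable value, and one limit covers them all: the limit of > 200000 nM in this assay, at which 4 of the 4 values shown sit.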